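A few compounds are considered here, and "the series" means these few. Any claim that something is new, unique, unknown or untested is made for them only; others in the source may bear on it.

Measured in a physicochemical assay for solubility, read by HPLC, using the shake flask method, measured as kinetic solubility, with a stated time of 20 h, at pH 6.5, tested at 200 uM; a lower number here means a less soluble compound, a higher number a more soluble compound:
- compound 1 `O=S(=O)(c1cccc(Nc2ccc3nccc(-c4ccncc4)c3n2)c1)N1CCCCC1`: 15000 nM
- compound 2 `NCCNS(=O)(=O)c1cccc(Nc2ccc3nccc(-c4ccncc4)c3n2)c1`: 200000 nM

Of these two numbers, compound 2 holds the higher, at 200000 nM. Next comes compound 3 `O=S(=O)(NCc1ccccc1)c1cccc(Nc2ccc3nccc(-c4ccncc4)c3n2)c1`, with this change: phenyl in place of aminomethyl on a saturated chain carbon bound to a sulfonamide nitrogen. That is, phenyl in place of aminomethyl on a saturated chain carbon bound to a sulfonamide nitrogen.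

Going by the values given here, the only measured step that bears on it is a 13-fold higher number from compound 1 to compound 2 (1.12 log units; beyond the scatter), which is large and has (2-aminoethyl)amino in place of piperidin-1-yl on a sulfonyl sulfur. Compound 3 no longer carries the 2-aminoethyl group, so a large drop is expected in this assay. The estimated step is a 25-fold lower number from compound 2 to compound 3 (1.40 log units; beyond the scatter). For compound 3 the expected value is 8000 nM, with an estimated range of 2000 nM to 30000 nM.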

Compound 3, solubility: < 5000 nM
Compound 3 was reported as a limit (the forecaster's own chance of this, stated with the estimate: 10%); at least 1.6-fold (0.20 log units) between middle value and limit.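

In this assay, compound 3 is reported only as a limit, not a number: the limit of < 5000 nM in this assay, at which 1 of the 3 values shown sits. Phenyl in place of aminomethyl on this saturated chain carbon gives an at least 40-fold lower number from compound 2 to compound 3 (1.60 log units; beyond the scatter), so the high reading does not survive this change. Benzylamino on the sulfonyl sulfur also sits under the piperidin-1-yl group, with an at least 3.0-fold lower number from compound 1 to compound 3 (0.47 log units; beyond the scatter), so a sulfonamide nitrogen hydrogen alone does not go with a high number in these compounds.

Open, going by these compounds, is whether the terminal amine itself is required: a hydroxyl, a carboxylic acid or a longer aminoalkyl chain at this place would separate these readings.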